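This account rests on a few compounds, and the source may have more. Where it says the series, first, only, none or still open, it means among the compounds named here.

Measured in a functional assay on HepG2 cells (Homo sapiens) for antiproliferative activity, read by MTT assay, with a stated time of 24 h; a higher number here means a weaker inhibitor, a lower number a stronger inhibitor:
Compound 1 `COc1cc(OC)c(-c2coc3cc(OCc4ccccc4)ccc3c2=O)cc1OC`: 1320 nM
Compound 2 `COc1cc(OC)c(-c2coc3cc(OCc4ccc(F)cc4)ccc3c2=O)cc1OC`: 1000 nM
Compound 3 `COc1cc(OC)c(-c2coc3cc(OCc4cccc(Cl)c4)ccc3c2=O)cc1OC`: 750 nM

Compound 2 stands second highest of these three numbers. Its nearest neighbour is compound 1, with a 1.3-fold lower number from compound 1 to compound 2 (0.12 log units; within the scatter); its furthest is compound 3, with a 1.3-fold lower number from compound 2 to compound 3 (0.12 log units; within the scatter). Compound 4 `COc1cc(OC)c(-c2coc3cc(OCc4cccc(C(F)(F)F)c4)ccc3c2=O)cc1OC` has not yet been measured in this assay. Relative to compound 2 the change is 3-(trifluoromethyl)phenyl in place of 4-fluorophenyl on a saturated chain carbon bound to an oxygen on an aromatic ring. Going by the values given here, three measured steps bear on it: a 1.3-fold lower number from compound 1 to compound 2 (0.12 log units; within the scatter), a 1.8-fold lower number from compound 1 to compound 3 (0.25 log units; within the scatter) and a 1.3-fold lower number from compound 2 to compound 3 (0.12 log units; within the scatter), every one of them within the scatter. Nothing here points to a step beyond the scatter, so compound 4 is expected to sit close to compound 2 and compound 3, with a 1.3-fold lower number from compound 2 to compound 4 (0.10 log units; within the scatter). The estimate for compound 4 in this assay is 800 nM, expected to fall between 400 nM and 1600 nM.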

Compound 4, half-maximal inhibitory concentration: 610 nM
Beside the measured number, compound 4's estimate is 1.3-fold (0.12 log units) above it; low and high end bracket the measured number.
By their numbers in this assay, from the lowest: compounds 4, 3, 2 and 1 (each within the scatter of the next, the first and the last beyond it).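

In this assay, going by these compounds alone, trifluoromethyl in place of hydrogen on the benzyl group gives the only step in this set that lies beyond the scatter, and it is a modest one (a 2.2-fold lower number from compound 1 to compound 4 (0.34 log units; beyond the scatter)). Against the other substituted benzyl groups, the new group stays within the scatter (a 1.6-fold lower number from compound 2 to compound 4 (0.21 log units; within the scatter); a 1.2-fold lower number from compound 3 to compound 4 (0.09 log units; within the scatter)), so these three substituted compounds cannot be ranked. No measurement here explains the step. The compounds shown leave open how an amine, a carboxylic acid or a methoxy group would behave on this benzyl group, and whether a longer chain in place of the benzyl carbon would change the result.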